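The source may hold more compounds than are shown below. What is called first, only, known or untested is meant among the compounds shown, and "the series" means these compounds.

Compound 1 `COC(=O)C1=C(C)N=C(C)/C(=C(\O)OC)C1c1ccccc1F`: 42.7 nM
Compound 2 `CCc1ccccc1C1C(C(=O)OC)=C(C)N=C(C)/C1=C(\O)OC`: 6.46 nM
Compound 3 `COC(=O)C1=C(C)N=C(C)/C(=C(\O)OC)C1c1cccc(C(F)(F)F)c1`: 74.1 nM

All three values come from a functional assay (muscle tissue) with Cavia porcellus as the target; a higher number here means that more compound is needed for the effect, a lower number that less compound is needed. Compound 3, at 74.1 nM, cannot be told apart from compound 1, at 42.7 nM, because the two lie within the usual scatter. Compound 2 shows a clearly lower number, 6.46 nM, than either of them.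

The next compound is compound 4 `COC(=O)C1=C(C)N=C(C)/C(=C(\O)OC)C1c1cccc(C#N)c1`, which has cyano in place of trifluoromethyl on an aromatic carbon.

Going by the values given here, only one measured step links two compounds that differ in a single place: a 6.6-fold lower number from compound 1 to compound 2 (0.82 log units; beyond the scatter), with ethyl in place of fluoro on an aromatic carbon. That step shows that a swap of this kind can move the number, but it involves neither trifluoromethyl nor cyano, so it gives no direction here. With so little to go on, no clear shift is expected.

The step expected in this assay is a 1.5-fold lower number from compound 3 to compound 4 (0.17 log units; within the scatter), which would not stand out from the scatter.

Compound 4 is estimated at 50 nM, with an expected range from 15 nM to 170 nM.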

Compound 4, half-maximal effective concentration: 34.7 nM
The estimate for compound 4 lay 1.4-fold (0.16 log units) above the measured number; the measured number falls inside the stated range.
By their numbers in this assay, from the lowest: compound 2; then compounds 4, 1 and 3 (each within the scatter of the next, the first and the last beyond it).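

In this assay, cyano in place of trifluoromethyl on the same aromatic carbon gives a 2.1-fold lower number from compound 3 to compound 4 (0.33 log units; beyond the scatter), so the group at this position can change the number, though only modestly. Replacing 2-fluorophenyl with 3-cyanophenyl gives a 1.2-fold lower number from compound 1 to compound 4 (0.09 log units; within the scatter), which cannot be told apart from no change, while replacing 2-ethylphenyl with 3-cyanophenyl gives a 5.4-fold higher number from compound 2 to compound 4 (0.73 log units; beyond the scatter), so compound 2 keeps a clearly lower number than compound 4. Nothing measured here explains why these swaps move the number as they do.

From the compounds shown here alone, whether an amine or a carboxylic acid on this aromatic carbon would raise or lower the number stays open. So does whether the ethyl group of compound 2 would give a similarly low number on this same carbon.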